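A few compounds are considered here, and "the series" means these few. Any claim that something is new, unique, unknown or untested is made for them only; others in the source may bear on it.

Compound 1 `CC1(C)Cc2c(OCc3ccccc3)ccc(C(=O)/C=C/c3ccc(Cl)cc3Cl)c2O1` is a chalcone-type molecule in which a 2,4-dichlorophenyl group sits at one end of the double-bonded chain and a benzyloxy group sits on the shared core. In a functional assay on PC-3 cells (Homo sapiens) for antiproliferative activity, read by MTT assay, with a stated time of 48 h (a lower number here means a stronger inhibitor, a higher number a weaker inhibitor), compound 1 gives only a limit of the assay, > 100000 nM, so that its true potency is not known beyond that boundary (the limit of > 100000 nM in this assay, at which 1 of the 2 values shown sits). Compound 2 `COc1ccc(-c2nn(-c3ccccc3)cc2/C=C/C(=O)c2ccc(O)c3c2OC(C)(C)C3)cc1` carries a different arrangement at the far end of the chain and a free hydroxyl on the core; in this assay compound 2 gives 20800 nM. Compound 3 `COc1ccc(/C=C/C(=O)c2ccc(OCc3ccccc3)c3c2OC(C)(C)C3)cc1` keeps the core and benzyloxy group of compound 1 and changes only the aromatic ring on the chain: 4-methoxyphenyl in place of 2,4-dichlorophenyl on a double-bonded chain carbon bound to a double-bonded chain carbon. Among the compounds with values here, no measured step stands beside this change, so the direction can only be guessed. The expected step from compound 1 to compound 3 is an at least 2.0-fold lower number from compound 1 to compound 3 (0.30 log units; that floor lies within the scatter), pointing toward somewhat stronger inhibition but with little confidence. Compound 3 is therefore expected to give roughly 50000 nM, with a range from 10000 nM to 150000 nM.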

Compound 3, half-maximal inhibitory concentration: 13500 nM
Beside the measured number, compound 3's estimate is 3.7-fold (0.57 log units) above it; the range from low to high includes it.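

In this assay, putting 4-methoxyphenyl in place of 2,4-dichlorophenyl gives an at least 7.4-fold lower number from compound 1 to compound 3 (0.86 log units; beyond the scatter), the first measured sign that the aromatic ring at this place on the chain affects the read-out. The core and the benzyloxy group stay the same in both compounds, so this step belongs to the exchange of that one ring as a whole. Compound 1 stands at a limit of the assay and not at a number, so the step is a floor and the true gap may be larger: the limit of > 100000 nM in this assay, at which 1 of the 3 values shown sits.

The compounds shown do not separate the loss of the two chlorine atoms from the arrival of the methoxy group, so it stays open which of these carries the step. Also open, on these data alone, is whether a plain phenyl ring, a dimethylamino group or a carboxylic acid at the same place would extend or reverse the step, and whether the same exchange would hold with a free hydroxyl on the core in place of the benzyloxy group.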